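The compounds below may be only part of what the source reports. "The series", "measured", "known", "first", "only" and "open" are said of these compounds alone.

Compounds measured in a functional assay on MDA-MB-435 cells (Homo sapiens) for inhibition, read by sulforhodamine B assay, with a stated time of 48 h, tested at 10 uM; on this read-out higher numbers stand for more inhibition at the one concentration tested (going by the name of the read-out) and lower numbers for less inhibition:
compound 1 `c1ccc(-c2cn3ccnc3c(-c3ccc4ncn(C5CCCCC5)c4c3)n2)cc1`, 28.7%;
compound 2 `COc1ccc(-c2cn3ccnc3c(-c3ccc4ncn(C5CCCCC5)c4c3)n2)cc1`, -18.6%;
compound 3 `CCc1ccc(-c2cn3ccnc3c(-c3ccc4ncn(Cc5ccccc5)c4c3)n2)cc1`, 50.9%.

Compound 3 stands highest of the three; compound 1 sits beyond the scatter below it, and compound 2 furthest below it. Compound 4 `Cc1cccc(-c2cn3ccnc3c(-c3ccc4ncn(Cc5ccccc5)c4c3)n2)c1` is not yet measured. It differs from compound 3 by 3-methylphenyl in place of 4-ethylphenyl on an aromatic carbon. Going by the values given here, the only step on a single change is a number 47.3 percentage points lower from compound 1 to compound 2 (beyond the scatter), which shows that altering the substituent on this phenyl ring can move this assay far. The present change swaps one small alkyl group for another at a different position, so a moderate fall is expected: a number 15.9 percentage points lower from compound 3 to compound 4 (beyond the scatter), giving compound 4 an estimated 35% with a range from 5% to 60%.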

Compound 4, a percentage reported as inhibition, at one concentration (the size of the read-out at that concentration, not a potency): 0.94%
Compound 4: the middle estimate sits 34.1 percentage points above what was measured; the whole stated range lies above it.
By their numbers in this assay, from the lowest: compound 2; then compound 4; then compound 1; then compound 3.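

In this assay, a number 50 percentage points lower from compound 3 to compound 4 (beyond the scatter), so exchanging 4-ethylphenyl for 3-methylphenyl, a swap between two carbon-only groups, is enough to produce a large step. This change alters both the place of the alkyl group on the phenyl ring and its size, and it stands as a second large step at this position beside the methoxy change, a number 47.3 percentage points lower from compound 1 to compound 2 (beyond the scatter). No available evidence explains the step. The compounds shown leave open whether the place of the group or the length of the chain accounts for it. They also leave open how an amine or a carboxylic acid on this phenyl ring would read.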